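Adding a Second Hydroxy Group to the Far Ring

A few compounds are considered here, and "the series" means these few. Any claim that something is new, unique, unknown or untested is made for them only; others in the source may bear on it.

Compound 1 `O=C(/C=C(O)/C=C/c1ccc(O)cc1)c1cc(Cl)ccc1O` carries one hydroxy group on its far ring, but in an assay on isolated protein for inhibition of Alpha glucosidase (Homo sapiens), with stated times of 5 min and 15 min (on this read-out higher numbers stand for weaker inhibition and lower numbers for stronger inhibition), compound 1 gives "not determined" (no result reported). Among the measured compounds shown here, compound 2 `O=C(/C=C(O)/C=C/c1cccc(O)c1)c1cc(Cl)ccc1O` gives 36400 nM in this assay, the only number obtained for this pair. Compound 3 `O=C(/C=C(O)/C=C/c1ccc(O)c(O)c1)c1cc(Cl)ccc1O` differs from compound 2 by hydroxy in place of hydrogen on an aromatic carbon. For the measured compounds named here, no step between measured compounds is available here, so the expectation rests on the structural change alone. The step of a 2.0-fold lower number from compound 2 to compound 3 (0.31 log units; beyond the scatter) is expected to run toward stronger inhibition, modestly beyond the usual scatter. Compound 3 is therefore estimated at 18000 nM, with a range from 6000 nM to 55000 nM.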

Compound 3, half-maximal inhibitory concentration: 15100 nM
Beside the measured number, compound 3's estimate is 1.2-fold (0.08 log units) above it; measured number inside the range.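

In this assay, hydroxy on an aromatic carbon, ortho to a hydroxy group and para to a large group, gives a 2.4-fold lower number from compound 2 to compound 3 (0.38 log units; beyond the scatter) and so shows that this position accepts the added group with a modest gain in inhibition. Compound 1 offered no such comparison, having no number of its own. Nothing measured here accounts for this gain. The compounds shown leave open whether the gain requires hydroxy itself, or whether a methoxy group or an amine on the same carbon would serve equally well.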